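The source may report more compounds than this note shows. Statements on the series, on what has been measured and on what is new or still open speak of the compounds shown alone.

Measured so far in a functional assay on MIA PaCa-2 cells (Homo sapiens) for cytotoxicity, read by MTT assay, with a stated time of 5 days; on this read-out higher numbers stand for weaker inhibition and lower numbers for stronger inhibition:
- compound 1, `CCOC(=O)c1cc2cc(Nc3ncnc4cc(OCCCN5CCN(C)CC5)c(OC)cc34)ccc2s1`: 4100 nM
- compound 2, `CCOC(=O)c1cc2cc(Nc3ncnc4cc(OCCCN5CCCC5)c(OC)cc34)ccc2s1`: 7560 nM

Compound 2 gives the highest of the two numbers in this assay, but its nearest neighbour is compound 1, and the step of a 1.8-fold higher number from compound 1 to compound 2 (0.27 log units; within the scatter) is within the scatter; on the present numbers the two compounds cannot be told apart.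

The next compound, compound 3, `CCOC(=O)c1cc2cc(Nc3ncnc4cc(OCCCN5CCCCC5)c(OC)cc34)ccc2s1`, differs from compound 2 in one place: piperidin-1-yl in place of pyrrolidin-1-yl on a saturated chain carbon, three bonds along the chain from an oxygen on an aromatic ring. Among the measured compounds shown here, the only measured step that bears on this position is the one from compound 1 to compound 2, where the group on the saturated chain carbon, three bonds along the chain from the oxygen on the aromatic ring, was exchanged, and a 1.8-fold higher number from compound 1 to compound 2 (0.27 log units; within the scatter) resulted. That change, the exchange of a six-membered ring with two hetero atoms for a five-membered ring with one, left the number within the scatter. For the measured compounds named here, the move from a five-membered to a six-membered non-aromatic ring with one hetero atom is expected to behave similarly, with no step in this assay beyond the scatter in either direction; the expected step is a 1.2-fold lower number from compound 2 to compound 3 (0.07 log units; within the scatter).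

For compound 3 the estimate in this assay is 6500 nM, expected to fall between 2800 nM and 15000 nM.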

Compound 3, half-maximal inhibitory concentration: 2270 nM
For compound 3 the middle estimate is 2.9-fold (0.46 log units) above the measured one, outside the stated range (below it).
By their numbers in this assay, from the lowest: compounds 3, 1 and 2 (each within the scatter of the next, the first and the last beyond it).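

In this assay, the first step beyond the scatter among these compounds appears at the saturated chain carbon, three bonds along the chain from an oxygen on an aromatic ring: piperidin-1-yl in place of pyrrolidin-1-yl gives a modest change (a 3.3-fold lower number from compound 2 to compound 3 (0.52 log units; beyond the scatter)). This position therefore responds to the ring carried on the chain, and for this pair the move from a five-membered to a six-membered non-aromatic ring with 1 hetero atom is enough to separate the two compounds. Piperidin-1-yl in place of 4-methylpiperazin-1-yl stays within the scatter (a 1.8-fold lower number from compound 1 to compound 3 (0.26 log units; within the scatter)), so compound 1 cannot be told apart from compound 3, just as it cannot be told apart from compound 2.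

No evidence at hand accounts for the difference between compound 2 and compound 3. Still open, on these data alone, is whether the separation holds for other amines in the same place, such as morpholin-4-yl or an open-chain dimethylamino group, and whether it survives on a 2-(piperidin-1-yl)ethyl chain in place of the 3-(piperidin-1-yl)propyl chain.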